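Swapping a Halogen on a Second Core

This account rests on a few compounds, and the source may have more. Where it says the series, first, only, none or still open, it means among the compounds named here.

Of the compounds shown here, three have been tested in a functional assay on the whole organism (strain CF-1 albino) with Mus musculus as the target, with a stated time of 4 h; a higher number here means that more compound is needed for the effect, a lower number that less compound is needed. Compound 1, `O=C1CC(c2ccccc2F)C(=O)N1CN1CCN(c2cccc(C(F)(F)F)c2)CC1`, gives 100 mg/kg in this assay. Compound 2, `O=C1CC(c2ccccc2Br)C(=O)N1CN1CCN(c2cccc(C(F)(F)F)c2)CC1`, gives 300 mg/kg. The only difference between them is bromo in place of fluoro on an aromatic carbon, and this one change made the step of a 3.0-fold higher number from compound 1 to compound 2 (0.48 log units; beyond the scatter).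

Compound 3, `O=C1CC(c2ccccc2F)C(=O)N1CN1CCN(c2ncccn2)CC1`, carries a different core: compared with compound 1 it shows the change (pyrimidin-2-yl in place of 3-(trifluoromethyl)phenyl on an amine nitrogen in a ring). In this assay compound 3 gives 100 mg/kg, so the step of no change at the digits printed from compound 1 to compound 3 (within the scatter), and the two cores behave alike at this point.

Compound 4, `O=C1CC(c2ccccc2Br)C(=O)N1CN1CCN(c2ncccn2)CC1`, has not yet been measured. It stands to compound 3 exactly as compound 2 stands to compound 1: the change is bromo in place of fluoro on an aromatic carbon, and the surroundings of the exchanged atom are the same in both pairs, so this is the same change made on the core of compound 3 instead of the core of compound 1.

Since the two cores gave the same number in compounds 1 and 3, the simplest expectation is that the halogen swap repeats its earlier effect. The step from compound 3 to compound 4 is therefore expected to be about a 3.0-fold higher number from compound 3 to compound 4 (0.48 log units; beyond the scatter) in this assay, because the same change gave a 3.0-fold higher number from compound 1 to compound 2 (0.48 log units; beyond the scatter). On that basis compound 4 is estimated to need roughly 300 mg/kg in this assay, with a plausible range from 150 mg/kg to 600 mg/kg, resting on a single earlier example of the change.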

Compound 4, minimum effective dose: 100 mg/kg
Estimate against measurement, compound 4: 3.0-fold (0.48 log units) above; the measured number lies below the stated range.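

In this assay, the same halogen swap on the core of compound 3 gave no change at the digits printed from compound 3 to compound 4 (within the scatter), so the rise seen on the core of compound 1 did not carry over: the same change on two cores in this assay, a 3.0-fold higher number (0.48 log units; beyond the scatter) from compound 1 to compound 2 and no change at the digits printed (within the scatter) from compound 3 to compound 4, 3.0-fold (0.48 log units) apart, beyond the scatter of two such steps

Read the other way, putting pyrimidin-2-yl in place of 3-(trifluoromethyl)phenyl gave a 3.0-fold lower number from compound 2 to compound 4 (0.48 log units; beyond the scatter), although the same exchange had made no difference among the fluoro compounds: the same change on two cores in this assay, no change at the digits printed (within the scatter) from compound 1 to compound 3 and a 3.0-fold lower number (0.48 log units; beyond the scatter) from compound 2 to compound 4, 3.0-fold (0.48 log units) apart, beyond the scatter of two such steps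

Within these compounds, then, the effect of one change depends on what sits elsewhere in the molecule, so a step measured on one core cannot simply be copied to another; what this does not show is the reason for the difference, or whether it is general, as it rests on a single pair of steps.

Going by these compounds, whether chloro or a methoxy group in place of the halogen would follow compound 2 or compound 4 remains open, as does the behaviour of a plain phenyl group in place of pyrimidin-2-yl. Also open, on these data alone, is whether this dependence on the core would appear with a longer chain in place of the short link that joins the two halves of these molecules.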